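The compounds below may be only part of what the source reports. "The series", "measured", "known", "first", "only" and "open" are said of these compounds alone.

Working notes on the series. Compound 2 `CCN(CC)CCCCN(C[C@H]1Cc2ncccc2CN1)[C@H]1CCCc2cccnc21` in an ADME assay for permeability, using PAMPA, with a stated time of 4 h, at pH 5.5 (a higher number here means that the compound crosses the layer faster, a lower number that the compound crosses the layer more slowly), gives 3 nm/s; compound 1 `CN(C)CCCCN(C[C@H]1Cc2ncccc2CN1)[C@H]1CCCc2cccnc21` in this assay gives 2 nm/s, and the two numbers sit within the scatter of each other, as a 1.5-fold higher number from compound 1 to compound 2 (0.18 log units; within the scatter) shows. Compound 3 `c1cnc2c(c1)CN[C@@H](CN(CCCC1CCNCC1)[C@H]1CCCc3cccnc31)C2` differs from compound 2 by piperidin-4-yl in place of (diethylamino)methyl on a saturated chain carbon, three bonds along the chain from an amine nitrogen. Among the measured compounds shown here, the one measured step also alters the terminal amine, yet it exchanges one tertiary amine for another, while here a ring with a hydrogen-bond donor enters; so the step from compound 1 to compound 2 bears on it only loosely, and it stayed within the scatter. For the measured compounds named here, no measured pair here carries an added hydrogen-bond donor, so the direction is uncertain; a small downward shift, or none beyond the scatter, is expected, so that a 1.5-fold lower number from compound 2 to compound 3 (0.18 log units; within the scatter) is the estimated step. Compound 3 is therefore estimated at 2 nm/s, with a range from 0.7 nm/s to 5 nm/s.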

Compound 3, apparent permeability: 14 nm/s
The estimate for compound 3 lay 7.0-fold (0.85 log units) below the measured number, and the stated range ends below it.
By their numbers in this assay, from the lowest: compounds 1 and 2 (each within the scatter of the next); then compound 3.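

In this assay this position now shows a change beyond the scatter, which the exchange of one terminal tertiary amine for another did not show: the earlier step was a 1.5-fold higher number from compound 1 to compound 2 (0.18 log units; within the scatter), while piperidin-4-yl gives a 4.7-fold higher number from compound 2 to compound 3 (0.67 log units; beyond the scatter) and also a 7.0-fold higher number from compound 1 to compound 3 (0.85 log units; beyond the scatter). The group leaving and the group entering have the same heavy-atom count, so this step comes with a different arrangement of those atoms, one six-membered non-aromatic ring and 1 hydrogen-bond donor, and not with added size. No available measurement accounts for the rise.

The compounds shown leave open whether the ring or the ring's hydrogen-bond donor goes with the higher number. 1-Methylpiperidin-4-yl, a tertiary amine within the same ring, and pyrrolidin-3-yl, a smaller ring with a secondary amine, remain open at this position.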